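This account rests on a few compounds, and the source may have more. Where it says the series, first, only, none or still open, it means among the compounds named here.

Compound 2 `FC(F)(F)c1cccc(-c2nc3cnc(Nc4cnccn4)cc3[nH]2)c1` is measured in a physicochemical assay for solubility, using the shake flask method, in phosphate buffer, measured as kinetic solubility, with a stated time of 20 h, at pH 6.5; on this read-out higher numbers stand for higher solubility and lower numbers for lower solubility. In this assay compound 2 gives < 5000 nM, which is a limit of the assay rather than a number. Within the data shown here, compound 1 `COc1ccnc(Nc2cc3[nH]c(-c4cccc(C(F)(F)F)c4)nc3cn2)c1` is the only other compound measured. In this assay compound 1 gives < 5000 nM, also a limit. The step that the two limits leave unreadable from compound 1 to compound 2 therefore cannot be read, and the limit of < 5000 nM in this assay, at which 2 of the 2 values shown sit, is all the record holds. Compound 3 `O=C(O)c1ccc(Nc2cc3[nH]c(-c4cccc(C(F)(F)F)c4)nc3cn2)nc1` differs from compound 2 by 5-carboxypyridin-2-yl in place of pyrazin-2-yl on a nitrogen on an aromatic ring. No readable step bears on this change, so neither its direction nor its size can be drawn from the measured compounds. The estimate for compound 3 in this assay is 10000 nM, expected between 1500 nM and 70000 nM. The step estimated is an at least 2.0-fold higher number from compound 2 to compound 3 (0.30 log units; that floor lies within the scatter).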

Compound 3, solubility: 6000 nM
The estimate for compound 3 lay 1.7-fold (0.22 log units) above the measured number; measured number inside the range.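

Compound 3 is the first compound here to give a number rather than a limit in this assay, while the other two remain at a limit of the assay: the limit of < 5000 nM in this assay, at which 2 of the 3 values shown sit.

In place of pyrazin-2-yl, 5-carboxypyridin-2-yl gives an at least 1.2-fold higher number from compound 2 to compound 3 (0.07 log units; that floor lies within the scatter), and in place of 4-methoxypyridin-2-yl it gives an at least 1.2-fold higher number from compound 1 to compound 3 (0.07 log units; that floor lies within the scatter). As far as these compounds go, both are only floors, so the full size of each step stays unknown, and the step between the two limits cannot be read.

From the compounds shown here alone, what an ester, an amide or an amine in place of the carboxylic acid would give stays open. So does whether the carboxylic acid or the ring carrying it accounts for these steps.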